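The source may hold more compounds than are shown below. What is called first, only, known or untested is meant among the compounds shown, and "the series" means these compounds.

Compound 1, `Cc1ccc2c(Cc3nn4c(C=O)c(-c5ccc(Cl)cc5)nc4s3)coc2c1`, carries a formyl group on the shared core. In a functional assay on the whole organism (strain Wistar albino) for inhibition, with Rattus norvegicus as the target, read by paw edema, with a stated time of 1 h, at a dose of 100 mg/kg by the oral route (on this read-out lower numbers stand for less inhibition and higher numbers for more inhibition at the one dose given (going by the name of the read-out)), compound 1 gives 11.4%. Compound 2, `Cc1ccc2c(Cc3nn4c(CO)c(-c5ccc(Cl)cc5)nc4s3)coc2c1`, carries a hydroxymethyl group at the same place, and in this assay compound 2 gives 14.5%. The only step measured so far is a number 3.1 percentage points higher from compound 1 to compound 2 (within the scatter), so on the numbers shown compound 2 and compound 1 lie within the scatter of each other, and the inhibition in this assay is level between the two.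

Compound 3, `Cc1ccc2c(Cc3nn4c(/C=N/O)c(-c5ccc(Cl)cc5)nc4s3)coc2c1`, differs from compound 2 in one place: a group of 3 heavy atoms (1 carbon, 1 nitrogen, 1 oxygen; no ring) in place of a group of 2 heavy atoms (1 carbon, 1 oxygen; no ring), on an aromatic carbon. Within the data shown here, the one measured step bears on this change, because it swaps one small group for another at this same position and gave a number 3.1 percentage points higher from compound 1 to compound 2 (within the scatter), a step within the scatter. By that step, exchanging small oxygen-bearing groups at this position has not moved the read-out beyond its scatter, and compound 3 is therefore expected to stay close to compound 2, with an estimated step of a number 0.5 percentage points lower from compound 2 to compound 3 (within the scatter). For compound 3 the value in this assay is estimated at 14%, within a range of 5% to 24%.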

Compound 3, a percentage reported as inhibition, in the whole organism at one dose (the size of the read-out at that dose, not a potency): 5.19%
Compound 3: the middle estimate sits 8.8 percentage points above what was measured; low and high end bracket the measured number.
By their numbers in this assay, from the lowest: compounds 3, 1 and 2 (each within the scatter of the next).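

Among these compounds, with a third group on this aromatic carbon, one that brings a double bond outside the aromatic rings and a nitrogen atom, this assay still separates no pair of compounds: it gives a number 9.3 percentage points lower from compound 2 to compound 3 (within the scatter) and a number 6.2 percentage points lower from compound 1 to compound 3 (within the scatter). Formyl, hydroxymethyl and this group of 3 heavy atoms therefore stand level at this position, so a somewhat larger group with one more hydrogen-bond acceptor has not shifted the inhibition beyond the scatter at this one dose and time. Nothing measured here offers an explanation of how these groups compare in the read-out.

Still open, on these data alone, is whether a more different group at this place, such as an amine, a carboxylic acid or a longer chain, would take the read-out beyond the scatter of these three compounds. Also open is how much the 4-chlorophenyl group and the rest of the shared core contribute to the inhibition, as all the compounds shown keep those parts the same.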